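A few compounds are considered here, and "the series" means these few. Any claim that something is new, unique, unknown or untested is made for them only; others in the source may bear on it.

Measured compounds in an assay on HEK293 cells for displacement of a labelled ligand from Melanocortin receptor 4 (Homo sapiens); on this read-out higher numbers stand for weaker inhibition and lower numbers for stronger inhibition:
Compound 1 `COc1cc(CC(C)C(=O)N2CCN(c3ccc(C(F)(F)F)cc3[C@@H](N)CC(C)C)CC2)ccc1Cl` gives 230 nM.
Compound 2 `CC(C)C[C@H](N)c1cc(C(F)(F)F)ccc1N1CCN(C(=O)CCC(N)=O)CC1` gives > 10000 nM, which is a limit of the assay and not a number.
Compound 3 `CC(C)C[C@H](N)c1cc(C(F)(F)F)ccc1N1CCN(C(=O)CCC(=O)N(C)C)CC1` gives > 10000 nM, which is likewise a limit of the assay.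

Compound 3 therefore has no number of its own in this assay; it sits at the limit of > 10000 nM in this assay, at which 2 of the 3 values shown sit. Compound 4 `CC(C)C[C@H](N)c1cc(C(F)(F)F)ccc1N1CCN(C(=O)CNc2ccccc2)CC1` differs from compound 3 by anilino in place of (dimethylcarbamoyl)methyl on a saturated chain carbon bound to a carbonyl carbon. Of the measured steps, the one that bears on this change is an at least 43-fold higher number from compound 1 to compound 3 (1.63 log units; beyond the scatter), where the loss of the 1-(4-chloro-3-methoxybenzyl)ethyl group carried the value to the limit. The step that the two limits leave unreadable from compound 2 to compound 3 gives no readable size. Compound 4 again carries one six-membered aromatic ring on the chain, though as anilino rather than the group present in compound 1, so a move away from the limit is expected, of uncertain size. For compound 4 in this assay the estimate is 3000 nM, between 500 nM and 10000 nM, which is expected to mean an at least 3.3-fold lower number from compound 3 to compound 4 (0.52 log units; beyond the scatter).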

Compound 4, inhibition constant: 3600 nM
The estimate for compound 4 lay 1.2-fold (0.08 log units) below the measured number; measured number inside the range.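

In this assay, anilino on a saturated chain carbon bound to a carbonyl carbon is the first change shown that lifts a compound off the limit without the 1-(4-chloro-3-methoxybenzyl)ethyl group, giving an at least 2.7-fold lower number from compound 3 to compound 4 (0.44 log units; beyond the scatter) and an at least 2.7-fold lower number from compound 2 to compound 4 (0.44 log units; beyond the scatter). Anilinomethyl does not recover all that was lost with that group, however, as the change shows a 16-fold higher number from compound 1 to compound 4 (1.19 log units; beyond the scatter). The first two steps are lower bounds only, since compound 2 and compound 3 each stand at a limit and not a number: the limit of > 10000 nM in this assay, at which 2 of the 4 values shown sit.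

The compounds shown leave open whether the gain rests on the aromatic ring or on the anilino nitrogen, which a phenoxy group in place of anilino would help to separate. Also open, from the compounds shown here alone, is whether chloro and methoxy substituents on the anilino ring would close the remaining gap.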